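Where Compound 2 Stands Before Compound 3 Is Measured

The source may report more compounds than this note shows. Statements on the series, on what has been measured and on what is new or still open speak of the compounds shown alone.

Compound 1 `Clc1ccccc1/C=N/Cc1cccnc1`: 30 mg/kg
Compound 2 `C(=N/Cc1cccnc1)\c1ccccc1`: 100 mg/kg

Within the data shown here, in a functional assay on the whole organism (strain Swiss albino) with Mus musculus as the target, in the maximal electroshock model, with a stated time of 0.5 h (a higher number here means that more compound is needed for the effect, a lower number that less compound is needed), compound 2 holds the highest of the two numbers; the only measured step, a 3.3-fold higher number from compound 1 to compound 2 (0.52 log units; beyond the scatter), is the one separating them, and it concerns hydrogen in place of chloro on an aromatic carbon. Compound 3 `COc1ccccc1/C=N/Cc1cccnc1` differs from compound 2 by methoxy in place of hydrogen on an aromatic carbon. This puts a group back where compound 2 carries hydrogen, but a different group from the chloro of compound 1, so that step bears on it only loosely. A modest lowering is therefore expected, a 2.0-fold lower number from compound 2 to compound 3 (0.30 log units; within the scatter). Compound 3 is estimated at 50 mg/kg, ranging from 20 mg/kg to 150 mg/kg.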

Compound 3, minimum effective dose: 30 mg/kg
Beside the measured number, compound 3's estimate is 1.7-fold (0.22 log units) above it, within the range that was stated.
By their numbers in this assay, from the lowest: compounds 1 and 3 (each within the scatter of the next); then compound 2.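

At this aromatic carbon a second group, methoxy, now also gives a lower number than hydrogen in this assay, with a 3.3-fold lower number from compound 2 to compound 3 (0.52 log units; beyond the scatter) as its step. Methoxy in place of chloro gives no change at the digits printed from compound 1 to compound 3 (within the scatter), so the lowering seen earlier is not particular to chloro. No measured evidence on the cause accompanies this result. From the compounds shown here alone, whether an amine, a carboxylic acid or a longer chain such as butoxy at this carbon would match chloro and methoxy stays open. So does whether methoxy would give the same number elsewhere on the ring.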